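The compounds below may be only part of what the source reports. "The series", "measured", "known", "first", "only" and "open" are said of these compounds alone.

Measured compounds in an assay on HEK293 cells for inhibition of Steryl-sulfatase (Homo sapiens), tested at 0.1 uM; on this read-out higher numbers stand for a stronger effect at the one concentration tested and lower numbers for a weaker effect:
- compound 1, `NS(=O)(=O)Oc1ccc2c(c1)CN(C(=O)c1cccc(N3CCC(N4CCCCC4)CC3)c1)CC2`: 0%
- compound 2, `CN(C)CCCN(Cc1ccccc1)c1cccc(C(=O)N2CCc3ccc(OS(N)(=O)=O)cc3C2)c1`: 23.8%
- compound 3, `CCN(Cc1cccnc1)c1ccc(C(=O)N2CCc3ccc(OS(N)(=O)=O)cc3C2)cc1`: 35.7%

All three share the same sulfamate-bearing core, joined through an amide to an aryl ring that carries a substituted amino group. In this assay compound 3 stands highest of the three numbers; its gap to compound 2, the nearest, is beyond the scatter, and its gap to compound 1, the furthest, is wider still and likewise beyond the scatter. Compound 1, with a cyclic amine in place of the acyclic one, gives no inhibition at the concentration tested, while compound 2 and compound 3, which both carry a benzyl-type group on the aryl nitrogen, give measurable numbers.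

Compound 4, `CCN(Cc1ccc(F)cc1)c1ccc(C(=O)N2CCc3ccc(OS(N)(=O)=O)cc3C2)cc1`, has not yet been measured. It differs from compound 3 in one place: 4-fluorophenyl in place of pyridin-3-yl on a saturated chain carbon bound to a nitrogen on an aromatic ring. Among the compounds with values here, no pair of measured compounds differing only in this place is available, so the step cannot be read off directly.

The change is expected to leave the number near that of compound 3, with the step from a number 4.3 percentage points higher from compound 3 to compound 4 (within the scatter) expected to fall within or only slightly beyond the scatter, if anything upward. Compound 4 is therefore estimated at 40% in this assay, within a range from 22% to 58%.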

Compound 4, a percentage reported as inhibition, at one concentration (the size of the read-out at that concentration, not a potency): 69.1%
Compound 4: middle estimate off by 29.1 percentage points, on the low side; the whole stated range lies below it.
By their numbers in this assay, from the lowest: compound 1; then compound 2; then compound 3; then compound 4.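

Within the data shown here, at the place on a saturated chain carbon bound to a nitrogen on an aromatic ring, 4-fluorophenyl in place of pyridin-3-yl gives the first single-place comparison: in this assay, the change gives a number 33.4 percentage points higher from compound 3 to compound 4 (beyond the scatter). The earlier compounds shown here differ in more than one place and could not isolate this position, whereas this pair shows that the ring carried on the ethyl-substituted amino group has a large bearing on the read-out at the one concentration tested. The swap removes the ring nitrogen, with the one hydrogen-bond acceptor counted on the leaving group, and brings in fluorine in a single step, and nothing available here bears on why the number rises.

Which of these two differences carries the step stays open, and a plain phenyl at this place, with the rest of compound 4 kept, would separate them. Also open, from the compounds shown here alone, is whether the step extends to a non-aromatic ring such as cyclohexyl at this place, and how a propyl chain in place of the ethyl on the same nitrogen would read alongside 4-fluorophenyl.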